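A few compounds are considered here, and "the series" means these few. Any claim that something is new, unique, unknown or untested is made for them only; others in the source may bear on it.

Measured so far in a functional assay on MCF7 cells (Homo sapiens) for cytotoxicity, read by MTT assay, with a stated time of 24 h; a lower number here means a stronger inhibitor, a higher number a weaker inhibitor:
compound 1 `O=C(CN1CCN(c2ccccc2Cl)CC1)N1CCN(c2nnc(-c3ccccc3)c(-c3ccccc3)n2)CC1`: 263000 nM
compound 2 `COc1cccc(N2CCN(CC(=O)N3CCN(c4nnc(-c5ccccc5)c(-c5ccccc5)n4)CC3)CC2)c1`: a limit, > 910000 nM
compound 3 `COc1ccc(-c2nnc(N3CCN(C(=O)CN4CCN(c5ccccc5Cl)CC4)CC3)nc2-c2ccc(OC)cc2)cc1`: a limit, > 814000 nM

Compound 1 is the only one of the three with a number in this assay. For compound 2 the assay reports only a limit, > 910000 nM. Between the two, the change 3-methoxyphenyl in place of 2-chlorophenyl on an amine nitrogen in a ring gives an at least 3.4-fold higher number from compound 1 to compound 2 (0.53 log units; beyond the scatter). Compound 3 shares the chlorophenyl group of compound 1, but the difference between the two cores is not broken down here; for compound 3 the assay again reports only a limit, > 814000 nM.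

Compound 4 `COc1ccc(-c2nnc(N3CCN(C(=O)CN4CCN(c5cccc(OC)c5)CC4)CC3)nc2-c2ccc(OC)cc2)cc1` is not yet measured. It differs from compound 3 by 3-methoxyphenyl in place of 2-chlorophenyl on an amine nitrogen in a ring, the same change that was made from compound 1 to compound 2, at the same place. Since that change weakened inhibition once, and compound 3 already sits at a limit, compound 4 is expected to remain at or beyond a limit, an estimated step that the limit leaves unreadable from compound 3 to compound 4. In this assay compound 4 is estimated at 1500000 nM, within 600000 nM to 5000000 nM.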

Compound 4, half-maximal inhibitory concentration: > 821000 nM
Compound 4: a limit, no number; the forecaster's own chance of this, stated with the estimate: 85%; the middle value is on the limit's open side.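

Compound 3 and compound 4 each give only a limit, and the step between them cannot be read. From the compounds shown here alone, it stays open whether 3-methoxyphenyl in place of 2-chlorophenyl shifts the number on the core of compound 3 as it does on the core of compound 1.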